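This account rests on a few compounds, and the source may have more. Where it says the series, first, only, none or still open, it means among the compounds named here.

Of the compounds shown here, three sharing a core have been tested so far: compound 1 `O=C(NNc1ccc(F)cc1)c1cccc(NS(=O)(=O)c2cnc(O)nc2O)c1`, compound 2 `O=C(NNC(=O)c1ccccc1F)c1ccc(NS(=O)(=O)c2cnc(O)nc2O)cc1` and compound 3 `CCCCOc1ccc(C(=O)NNC(=O)c2cccc(NS(=O)(=O)c3cnc(O)nc3O)c2)cc1`. In a functional assay on A549 cells (Homo sapiens) for antiproliferative activity, read by MTT assay, with a stated time of 24 h (a lower number here means a stronger inhibitor, a higher number a weaker inhibitor), compound 1 gives > 20000 nM, and this is a limit of the assay, not a number. Compound 2 gives 7610 nM and compound 3 gives 7760 nM. These two values lie within the usual scatter of each other, so compound 3 stands level with compound 2.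

Compound 4 `O=C(NNC(=O)c1cccc(NS(=O)(=O)c2cnc(O)nc2O)c1)c1ccc(F)cc1` has not been tested yet. It keeps the frame of compound 3 and changes one group: fluoro in place of butoxy on an aromatic carbon, para to a large group. Among the measured compounds shown here, no measured pair shows this kind of change, so any expectation here is loose. Compound 2 also carries a fluoro on an aromatic carbon and gives 7610 nM, so no step beyond the scatter is expected in this assay. The estimated step is a 1.2-fold higher number from compound 3 to compound 4 (0.09 log units; within the scatter). For compound 4 the estimated value is 9500 nM, with an expected range of 4500 nM to 20000 nM.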

Compound 4, half-maximal inhibitory concentration: > 20000 nM
Compound 4 ended at the assay's limit; the forecaster's own chance of this, stated with the estimate: 20%; middle value at least 2.1-fold (0.32 log units) from the limit.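

In this assay, fluoro in place of butoxy on an aromatic carbon, para to a large group, gives an at least 2.5-fold higher number from compound 3 to compound 4 (0.41 log units; beyond the scatter). Among the compounds shown here, this is the first measured pair with a change at this position, and it shows that the group held there can decide whether a value is reached within the range of this test, so the earlier match of compound 2 and compound 3 says little about this change. The step between compound 1 and compound 4 cannot be read, because each of the two compounds sits at a limit: the limit of > 20000 nM in this assay, at which 2 of the 4 values shown sit.

The compounds shown leave open how a methoxy group, a hexyloxy chain or an amine would behave at this position. They also cannot separate the length of the butyl chain from the oxygen that links it to the ring.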